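The source may hold more compounds than are shown below. What is called first, only, known or untested is meant among the compounds shown, and "the series" means these compounds.

Measured compounds in an ADME assay on MRC5 cells (Homo sapiens), read by MTT assay, with a stated time of 72 h; on this read-out lower numbers stand for stronger inhibition and higher numbers for weaker inhibition:
- compound 1 `O=c1[nH]cnc2c1c(-c1ccsc1)cn2[C@@H]1O[C@H](CO)[C@@H](O)[C@H]1O`: > 100000 nM
- compound 2 `Cc1nc(N)c2c(-c3cc4ccccc4o3)cn([C@@H]3O[C@H](CO)[C@@H](O)[C@H]3O)c2n1`: 91800 nM

Compound 1 sits at the limit of this assay, and its entry is a limit rather than a number (the limit of > 100000 nM in this assay, at which 1 of the 2 values shown sits). Among the compounds with values here, compound 2 gives a number at the weak end of the scale, and no step between these two measured compounds can be counted, since they differ in more than one place; the two values show only that both sit at or near the top of the range.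

The next compound in the series is compound 3 `O=c1[nH]cnc2c1c(-c1ccco1)cn2[C@@H]1O[C@H](CO)[C@@H](O)[C@H]1O`. It differs from compound 1 in one place: furan-2-yl in place of thiophen-3-yl on an aromatic carbon. Within the data shown here, no measured step of this kind is on hand, so the size of the change in this assay can only be expected, not read off.

The expectation is that the step from compound 1 to compound 3 in this assay is none beyond the scatter, with a number no higher from compound 1 to compound 3 (the limit leaves the size open) as the expected shift. Compound 3 is estimated at 100000 nM in this assay, with a range from 50000 nM to 300000 nM, and it is likely that the assay again reports only a limit for compound 3.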

Compound 3, half-maximal inhibitory concentration: > 100000 nM
Compound 3 ended at the assay's limit; the forecaster's own chance of this, stated with the estimate: 70%; the middle value sits exactly at the limit.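

Compound 1 and compound 3 both end at a limit rather than a number in this assay, so no step can be read between them: the limit of > 100000 nM in this assay, at which 2 of the 3 values shown sit.

The compounds shown leave open whether furan-2-yl in place of thiophen-3-yl on the shared core makes any difference in this assay.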